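This account rests on a few compounds, and the source may have more. Where it says the series, first, only, none or still open, it means among the compounds named here.

Series notes. In an ADME assay on HEK293 cells (Homo sapiens) for cytotoxicity, read by resazurin assay, with a stated time of 72 h (a higher number here means that more compound is tolerated, a lower number that less compound is tolerated), compound 1 (`CCNC(=O)c1ccc(CCOc2c(F)ccc3nc(C(=O)NCc4cccc(CC)c4)[nH]c(=O)c23)cc1`) gives > 20000 nM, a limit of the assay. Compound 2 (`CCc1cccc(CNC(=O)c2nc3cccc(COc4ccc(C(=O)O)cc4)c3c(=O)[nH]2)c1`) gives > 20000 nM, also a limit. Compound 3 (`O=C(O)c1ccc(COCc2cccc3nc(C(=O)NCc4ccccc4)[nH]c(=O)c23)cc1`) gives > 20000 nM, likewise a limit and not a number. Among the measured compounds shown here, compound 3 therefore stands only at a limit, as do the other two, and no measured step is available for sizing a change. Compound 4 (`O=C(O)c1ccc(COCc2cccc3nc(C(=O)NCc4cccc(C(F)(F)F)c4)[nH]c(=O)c23)cc1`) differs from compound 3 by trifluoromethyl in place of hydrogen on an aromatic carbon, meta to a large group. From compound 3, no step beyond the scatter is expected in this assay, in either direction, due to the limit of > 20000 nM in this assay, at which 3 of the 3 values shown sit. The estimated change is a number no higher from compound 3 to compound 4 (the limit leaves the size open). Compound 4 is estimated at 20000 nM, with an expected range of 9000 nM to 40000 nM.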

Compound 4, half-maximal cytotoxic concentration: > 20000 nM
Compound 4: no number, only a limit; the forecaster's own chance of this, stated with the estimate: 80%; the middle value sits exactly at the limit.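

Compound 4, like compound 3, stands only at a limit in this assay, so no step between the two can be read: the limit of > 20000 nM in this assay, at which 4 of the 4 values shown sit.

Still open is where any of these compounds falls as an actual number, and whether trifluoromethyl in place of hydrogen on an aromatic carbon shifts it.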